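The source may hold more compounds than are shown below. What is called first, only, known or untested is meant among the compounds shown, and "the series" means these compounds.

Measured so far:
compound 1 `CCCCc1ccc2[nH]c(-c3ccc(C(F)(F)F)cc3)c(C=O)c2c1`, 66 nM
compound 2 `CCCCc1ccc2[nH]c(-c3ccc(OC)cc3)c(/C=N/NC(=O)c3ccccc3)c2c1`, 130 nM

Two compounds sharing one core were tested in a functional assay on MCF7 cells (Homo sapiens) for antiproliferative activity, with a stated time of 5 days; on this read-out lower numbers stand for stronger inhibition and higher numbers for weaker inhibition. Compound 1 `CCCCc1ccc2[nH]c(-c3ccc(C(F)(F)F)cc3)c(C=O)c2c1` gave 66 nM in this assay. Compound 2 `CCCCc1ccc2[nH]c(-c3ccc(OC)cc3)c(/C=N/NC(=O)c3ccccc3)c2c1`, which carries a methoxy group on its pendant ring and a benzoyl hydrazone in place of the formyl group, gave 130 nM in this assay. Of the two numbers, that of compound 2 is the larger, but the gap to compound 1 is within the usual scatter, so the two cannot be told apart and neither can be called the more potent.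

The next compound, compound 3 `CCCCc1ccc2[nH]c(-c3ccc(OC)cc3)c(/C=N/NC(=O)c3cccnc3)c2c1`, has not yet been measured in this assay. It differs from compound 2 in one place: pyridin-3-yl in place of phenyl on a carbonyl carbon. For the measured compounds named here, no step between two measured compounds bears on this exact change, so the expectation rests on the two values alone. The replacement is expected to leave the number close to that of compound 2, with a step of a 1.2-fold higher number from compound 2 to compound 3 (0.06 log units; within the scatter) that is not expected to go beyond the scatter in either direction. Compound 3 is therefore estimated at 150 nM in this assay, within a range of 60 nM to 400 nM.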

Compound 3, half-maximal inhibitory concentration: 75 nM
Compound 3: the middle estimate sits 2.0-fold (0.30 log units) above what was measured, within the range that was stated.
By their numbers in this assay, from the lowest: compounds 1, 3 and 2 (each within the scatter of the next).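

In this assay, for the compounds shown here, the exchange of phenyl for pyridin-3-yl on the carbonyl carbon gives a 1.7-fold lower number from compound 2 to compound 3 (0.24 log units; within the scatter) and is the first step read at this position. It shows that a ring carbon can give way to a ring nitrogen here, adding one hydrogen-bond acceptor at the same count of heavy atoms, without a difference that can be told from the scatter. Nothing at hand explains this outcome or says what the ring nitrogen does here.

The compounds shown leave open whether a more drastic group on this carbonyl carbon, such as a piperidine, a carboxylic acid on the ring or a plain butyl chain in place of the ring, would move the number beyond the scatter, since a single exchange of one aromatic ring for another says little about the range this position tolerates. They also leave open what the methoxy group on the pendant ring contributes on its own, as compound 1 differs from the two hydrazones in two places and so gives no clean comparison with either.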